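A Smaller Group on the Five-Membered Ring

A few compounds are considered here, and "the series" means these few. Any claim that something is new, unique, unknown or untested is made for them only; others in the source may bear on it.

Compound 1 `CCCC(Oc1ccc(-n2cc(C(=O)N(C)C)cn2)cc1)c1ccc(C(=O)NCCC(=O)O)cc1` — 6500 nM
Compound 2 `O=C(O)CCNC(=O)c1ccc(C(Oc2ccc(-n3cc(C(F)(F)F)cn3)cc2)C2CCCC2)cc1` — 420 nM
Compound 3 `CCCC(Nc1ccc(-n2cnc(C(F)(F)F)c2)cc1)c1ccc(C(=O)NCCC(=O)O)cc1` — 680 nM

Of the compounds shown here, three have been measured in an assay on cells for displacement of a labelled ligand from Glucagon receptor (Homo sapiens), in the presence of a further agent that is not named here; a lower number here means a stronger inhibitor, a higher number a weaker inhibitor. Compound 1 gives 6500 nM, the highest number of the three, and so the weakest inhibition. Compound 2 gives 420 nM and compound 3 gives 680 nM; both of these lie below compound 1 by gaps well beyond the usual scatter, but each also differs from compound 1 in more than one place, so they do not isolate any single change.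

Compound 4 `CCCC(Oc1ccc(-n2cc(F)cn2)cc1)c1ccc(C(=O)NCCC(=O)O)cc1` differs from compound 1 in just one place: fluoro in place of dimethylcarbamoyl on an aromatic carbon. Going by the values given here, no measured pair shows this change on its own. What compounds 2 and 3 do show is that other groups at that position, in otherwise altered molecules, go with clearly lower numbers than compound 1. On that basis a drop in the number is expected, of moderate size and beyond the scatter, which is the step of a 3.6-fold lower number from compound 1 to compound 4 (0.56 log units; beyond the scatter). Compound 4 is estimated at 1800 nM, with a range from 500 nM to 6500 nM.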

Compound 4, inhibition constant: 1700 nM
The estimate for compound 4 lay 1.1-fold (0.02 log units) above the measured number; the range from low to high includes it.
By their numbers in this assay, from the lowest: compounds 2 and 3 (each within the scatter of the next); then compound 4; then compound 1.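

In this assay, fluoro in place of dimethylcarbamoyl gives a 3.8-fold lower number from compound 1 to compound 4 (0.58 log units; beyond the scatter) with the rest of the molecule unchanged, so a change at this aromatic carbon of the five-membered ring can now be read on its own. Dimethylcarbamoyl, with its five heavy atoms, is therefore not required here: a single fluorine atom at this carbon goes with stronger inhibition. No measurement at hand gives a reason for this step.

A plain hydrogen on that carbon would help separate what losing dimethylcarbamoyl does from what adding fluoro does. The compounds shown also leave open how a nitrile, a methyl or a trifluoromethyl at this carbon would compare on the otherwise unchanged core of compound 1.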